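A few compounds are considered here, and "the series" means these few. Any claim that something is new, unique, unknown or untested is made for them only; others in the source may bear on it.

In an ADME assay on cells (Fibroblast, Gallus gallus) for cytotoxicity, read by CCK-8 assay, with a stated time of 48 h (a higher number here means that more compound is tolerated, a lower number that less compound is tolerated), compound 1 (`CCC(CC)O[C@@H]1C=C(C(=O)O)C[C@H](NCc2ccc(Oc3ccccc3)cc2)[C@H]1NC(C)=O`) gives > 200000 nM as a limit and not a number. Compound 2 (`CCC(CC)O[C@@H]1C=C(C(=O)O)C[C@H](NCc2cccc(SC3CCCC3)c2)[C@H]1NC(C)=O`) gives > 200000 nM, also a limit. Compound 3 (`CCC(CC)O[C@@H]1C=C(C(=O)O)C[C@H](NCc2cccc(-c3ccc(SC)cc3)c2)[C@H]1NC(C)=O`) gives > 200000 nM, again a limit. Compound 1 therefore has no numerical position in the series (the limit of > 200000 nM in this assay, at which 3 of the 3 values shown sit). The change to compound 4 (`CCC(CC)O[C@@H]1C=C(C(=O)O)C[C@H](NCc2ccc(-c3cc4ccccc4s3)cc2)[C@H]1NC(C)=O`) is 1-benzothiophen-2-yl in place of phenoxy on an aromatic carbon. Among the measured compounds shown here, the one measured step (a step that the two limits leave unreadable from compound 2 to compound 3) also exchanges a group on an aromatic carbon, but it provides no readable size. No step beyond the scatter is expected in this assay for this change. The expected step (a number no higher from compound 1 to compound 4 (the limit leaves the size open)) is only an estimate. The estimated value for compound 4 is 200000 nM (expected range 90000 nM to 400000 nM).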

Compound 4, half-maximal cytotoxic concentration: > 200000 nM
Compound 4 ended at the assay's limit; the forecaster's own chance of this, stated with the estimate: 80%; the middle value lies on the limit itself.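

Among the compounds shown here, compound 1 and compound 4 both stand as limits, not numbers, in this assay, so no step between them can be read: the limit of > 200000 nM in this assay, at which 4 of the 4 values shown sit. The compounds shown leave open what numerical tolerated concentration any member of this series has.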